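The compounds below may be only part of what the source reports. "The series", "measured", "known", "first", "only" and "open" are said of these compounds alone.

Compound 1 `O=C(Nc1ccc(S(=O)(=O)NCc2ccccc2)cc1)c1ccc(Cl)cc1Cl`: in a functional assay on HEK293 cells for agonist activity at probable G-protein coupled receptor 27 (Homo sapiens), read by a luciferase reporter and beta-arrestin recruitment, with a stated time of 10 min (on this read-out lower numbers stand for an effect already at smaller amounts and higher numbers for an effect only at larger amounts of compound), compound 1 gives only the limit > 100000 nM.
Compound 2 `O=C(Nc1ccc(S(=O)(=O)Nc2cccc(Cl)c2)cc1)c1ccc(Cl)cc1Cl`: in this assay compound 2 gives 575 nM.
Compound 3 `O=C(Nc1ccc(S(=O)(=O)Nc2ccccc2)cc1)c1ccc(Cl)nc1F`: in this assay compound 3 gives 2290 nM.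

Compound 3 thus stands at the highest of the two numbers, with compound 2 lower, while compound 1 gave a limit rather than a number. Compound 4 `O=C(Nc1ccc(S(=O)(=O)Nc2ccccc2)cc1)c1ccc(Cl)cc1Cl` differs from compound 3 in one place: 2,4-dichlorophenyl in place of 6-chloro-2-fluoropyridin-3-yl on a carbonyl carbon. Going by the values given here, the only measured step, an at least 170-fold lower number from compound 1 to compound 2 (2.24 log units; beyond the scatter), changes the group on the sulfonamide nitrogen and not the group on the carbonyl carbon, so no measured step bears on this change. Compound 2 shares the 2,4-dichlorophenyl of compound 4 but carries a different sulfonamide substituent, so it gives only a loose pointer. The step of a 1.9-fold lower number from compound 3 to compound 4 (0.28 log units; within the scatter) is therefore expected to stay within the scatter. Compound 4 is estimated at 1200 nM, between 300 nM and 5000 nM.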

Compound 4, half-maximal effective concentration: 457 nM
Estimate against measurement, compound 4: 2.6-fold (0.42 log units) above; the measured number falls inside the stated range.
By their numbers in this assay, from the lowest: compounds 4 and 2 (each within the scatter of the next); then compound 3. At a limit, above all of these: compound 1.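

The group on the carbonyl carbon matters: 2,4-dichlorophenyl in place of 6-chloro-2-fluoropyridin-3-yl gives a 5.0-fold lower number from compound 3 to compound 4 (0.70 log units; beyond the scatter). Hydrogen in place of chloro on an aromatic carbon gives a 1.3-fold lower number from compound 2 to compound 4 (0.10 log units; within the scatter), so this chloro shows no clear effect in this pair. Phenyl in place of benzyl on the sulfonamide nitrogen gives an at least 210-fold lower number from compound 1 to compound 4 (2.34 log units; beyond the scatter), a step that starts from a limit: the limit of > 100000 nM in this assay, at which 1 of the 4 values shown sits.

On these data alone, the change on the carbonyl carbon swaps the ring atoms and halogens together, so which of them counts stays open. As far as these compounds go, how an amine or a carboxylic acid would fare in place of 2,4-dichlorophenyl is also open.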